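From nitro to methoxy on the aromatic ring

A few compounds are considered here, and "the series" means these few. Any claim that something is new, unique, unknown or untested is made for them only; others in the source may bear on it.

Compound 1 `Cn1cc([N+](=O)[O-])cc1C(=O)NNC(=S)Nc1ccc([N+](=O)[O-])cc1` gives 395000 nM as measured
Compound 2 `Cn1cc([N+](=O)[O-])cc1C(=O)NNC(=O)Nc1ccc(Cl)cc1` gives 290000 nM as measured

In an ADME assay on Vero cells (Chlorocebus sabaeus) for cytotoxicity, read by MTT assay, with a stated time of 72 h (a lower number here means a stronger inhibitor, a higher number a weaker inhibitor), compound 1 stands at 395000 nM and compound 2 at 290000 nM with the gap between them inside the usual scatter, so these two numbers cannot be told apart.

Compound 3 `COc1ccc(NC(=S)NNC(=O)c2cc([N+](=O)[O-])cn2C)cc1` has not been measured yet. It keeps the core of compound 1 but carries methoxy in place of nitro on an aromatic carbon, para to a large group (methoxy in place of nitro on an aromatic carbon). Going by the values given here, no measured pair shows what this single change does in this assay, so the data offer no direct guide, and no step beyond the scatter is expected. The estimate is a modest change (a 1.3-fold lower number from compound 1 to compound 3 (0.12 log units; within the scatter)) that stays within the scatter. For compound 3 the expected value is 300000 nM (120000 nM to 650000 nM).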

Compound 3, half-maximal inhibitory concentration: 184000 nM
For compound 3 the middle estimate is 1.6-fold (0.21 log units) above the measured one; measured number inside the range.
By their numbers in this assay, from the lowest: compounds 3, 2 and 1 (each within the scatter of the next, the first and the last beyond it).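

In this assay, going by these compounds alone, methoxy in place of nitro on an aromatic carbon, para to a large group, gives a 2.1-fold lower number from compound 1 to compound 3 (0.33 log units; beyond the scatter) and so provides the first single-change step at this position. The step is modest but lies beyond the scatter, which shows that the group at this position can move the number while the rest of the molecule stays the same. No supporting measurement accounts for this step, so it cannot be tied to any particular feature of nitro or methoxy.

This single pair leaves open how far the number would move with other groups at this position, such as an amine or a carboxylic acid. It also leaves open whether the same swap would produce a similar step on a different core.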